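Sulfonyl aryl swap on the shared core

The source may hold more compounds than are shown below. What is called first, only, known or untested is meant among the compounds shown, and "the series" means these compounds.

Of the compounds shown here, two have been measured in a functional assay on MCF7 cells (Homo sapiens) for cytotoxicity, with a stated time of 96 h; on this read-out lower numbers stand for stronger inhibition of growth and higher numbers for weaker inhibition of growth. Compound 1 `O=C(Oc1cccc2cccnc12)c1cc2c(cc1Cl)SC(N(c1ccc(F)cc1)S(=O)(=O)c1ccc(Br)s1)=NS2(=O)=O` gives 3200 nM and stands at the lowest number of the two; compound 2 `CCOC(=O)c1cc2c(cc1Cl)SC(N(c1ccc(OC)cc1)S(=O)(=O)c1ccc(Cl)cc1)=NS2(=O)=O` gives 8100 nM, a higher number, and the gap between them lies beyond the scatter. Compound 2 differs from compound 1 in more than one place, so no single step can be read from the pair. Compound 3 `O=C(Oc1cccc2cccnc12)c1cc2c(cc1Cl)SC(N(c1ccc(F)cc1)S(=O)(=O)c1ccc(Cl)cc1)=NS2(=O)=O` carries the change (4-chlorophenyl in place of 5-bromothiophen-2-yl on a sulfonyl sulfur). Among the measured compounds shown here, with no measured step on this change, the expected step of a 1.3-fold higher number from compound 1 to compound 3 (0.10 log units; within the scatter) is small, not clearly beyond the scatter. The estimate for compound 3 is 4000 nM, within 1600 nM to 10000 nM.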

Compound 3, concentration for 50% growth inhibition: 3200 nM
Compound 3: middle estimate off by 1.3-fold (0.10 log units), on the high side; low and high end bracket the measured number.
By their numbers in this assay, from the lowest: compounds 1 and 3 (each within the scatter of the next); then compound 2.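

In this assay, among the compounds shown here, the first readable step at the sulfonyl sulfur, 4-chlorophenyl in place of 5-bromothiophen-2-yl, reads no change at the digits printed from compound 1 to compound 3 (within the scatter). With the rest of compound 1 held fixed, this position therefore takes either aromatic ring without a shift beyond the scatter. Nothing available explains why the two groups read alike.

Still open, on these data alone, is whether a butyl chain or an amine on the sulfonyl sulfur would hold the read-out. The separate steps behind the several differences in compound 2 cannot be read.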